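The source may hold more compounds than are shown below. What is called first, only, known or untested is meant among the compounds shown, and "the series" means these compounds.

Compound 1 `COc1ccc(C2=[N+]3C(=Nc4c(-c5ccccc5)c5c(n4[B-]3(F)F)-c3ccc(OC)cc3CC5)C(c3ccccc3)=C2Br)cc1`: > 50000 nM
Compound 2 `COc1ccc2c(c1)CCc1c(-c3ccccc3)c3n(c1-2)[B-](F)(F)[N+]1=C(c2ccc(C)s2)C(Br)=C(c2ccccc2)C1=N3`: > 50000 nM
Compound 3 `COc1ccc(C2=[N+]3C(=Nc4c(-c5ccccc5)c5c(n4[B-]3(F)F)-c3ccc(OC)cc3CC5)C(c3ccccc3)=C2I)cc1`: > 50000 nM

In a toxicity assay on MCF7 cells (Homo sapiens) for cytotoxicity, read by MTT assay, with a stated time of 3 h (on this read-out higher numbers stand for weaker inhibition and lower numbers for stronger inhibition), compound 3 gives > 50000 nM, which is a limit of the assay and not a number. It is not alone there: the limit of > 50000 nM in this assay, at which 3 of the 3 values shown sit.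

Compound 4 `COc1ccc2c(c1)CCc1c(-c3ccccc3)c3n(c1-2)[B-](F)(F)[N+]1=C(c2cccs2)C(I)=C(c2ccccc2)C1=N3` carries one change (thiophen-2-yl in place of 4-methoxyphenyl on a carbon with a double bond to nitrogen), thiophen-2-yl in place of 4-methoxyphenyl on a carbon with a double bond to nitrogen. The closest measured swap, 5-methylthiophen-2-yl in place of 4-methoxyphenyl, is a step that the two limits leave unreadable from compound 1 to compound 2. Iodo in place of bromo is a step that the two limits leave unreadable from compound 1 to compound 3. Neither step has a readable size, and both end at the limit, so no step beyond the scatter is expected in this assay, in either direction. The estimate for compound 4 is 60000 nM, expected to lie between 25000 nM and 100000 nM, and most likely to be reported only as a limit.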

Compound 4, half-maximal inhibitory concentration: > 50000 nM
Compound 4 gave a limit, no number (the forecaster's own chance of this, stated with the estimate: 90%); the middle value lies beyond the limit too.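

No step can be read from compound 3 to compound 4, as each gives only a limit and not a number: the limit of > 50000 nM in this assay, at which 4 of the 4 values shown sit.

The compounds shown leave open whether any change to the shared core would give a readable number in this assay.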